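The source may report more compounds than this note shows. Statements on the series, on what has been measured and on what is new or still open speak of the compounds shown alone.

Working notes on the series.

Compound 1 `O=C1c2ccc(Cl)cc2CN1c1cccnc1` is the parent of the simple pair; in an assay on cells for inhibition of cytochrome P450 11B2, mitochondrial (Homo sapiens), read by HTRF (a lower number here means a stronger inhibitor, a higher number a weaker inhibitor), compound 1 gives 179 nM. Compound 2 `CC1c2cc(Cl)ccc2C(=O)N1c1cccnc1` carries a methyl on the saturated ring carbon of the same core, and in this assay compound 2 gives 123 nM. The pair differs by hydrogen in place of methyl on a saturated ring carbon, and the step of a 1.5-fold higher number from compound 2 to compound 1 (0.16 log units; within the scatter) is small.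

Compound 3 `CC(=O)N[C@@H]1CCCc2c1cncc2N1C(=O)c2ccc(Cl)cc2[C@H]1C` has a different core; how the two cores differ is not broken down here. In this assay compound 3 gives 130 nM, which sits with compound 2 and compound 1 inside the usual scatter, so no order among the three is claimed.

Compound 4 `CC(=O)N[C@@H]1CCCc2c1cncc2N1Cc2cc(Cl)ccc2C1=O` is the unmeasured analogue of compound 3, differing by hydrogen in place of methyl on a saturated ring carbon. This is the same kind of change as made from compound 2 to compound 1, with the ring atom that bears a large group in compound 3 standing where compound 2 has the ring atom that bears a pyridin-3-yl group (6 heavy atoms).

For the measured compounds named here, the expected step of a 1.5-fold higher number from compound 3 to compound 4 (0.16 log units; within the scatter) rests on the single earlier step of a 1.5-fold higher number from compound 2 to compound 1 (0.16 log units; within the scatter) and on compound 3 giving 130 nM. Compound 4 is therefore estimated at 190 nM, with a range of 90 nM to 400 nM.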

Compound 4, half-maximal inhibitory concentration: 44 nM
Compound 4: middle estimate off by 4.3-fold (0.64 log units), on the high side; the measured number lies below the stated range.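

On the second core, hydrogen in place of methyl on a saturated ring carbon gives a 3.0-fold lower number from compound 3 to compound 4 (0.47 log units; beyond the scatter) in this assay, so the step seen on the simple pair does not serve as a fixed increment for this change. Across the two cores shown, the size and direction of the step depend on the core that carries it: the same change on two cores in this assay, a 1.5-fold higher number (0.16 log units; within the scatter) from compound 2 to compound 1 and a 3.0-fold lower number (0.47 log units; beyond the scatter) from compound 3 to compound 4, 4.3-fold (0.63 log units) apart, beyond the scatter of two such steps With only two pairs, this shows that the change did not transfer between these two cores, but it does not show which structural difference between the cores accounts for the gap, nor how the change would behave on any third core.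

The compounds shown leave open whether a larger group on the same saturated ring carbon, such as ethyl, or a hydroxyl or an amine there, would follow the step on either core. They also leave open how much of the gap would remain on a core carrying a simpler chain than the acetamide, such as a free amine.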